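Swapping chloro for amino on a shared core

This account rests on a few compounds, and the source may have more. Where it says the series, first, only, none or still open, it means among the compounds named here.

Compound 1, `OCCOCn1c(Cl)nc2c(Cl)c(Cl)ccc21`, was tested in a functional assay on KB cells (Homo sapiens) for inhibition; a lower number here means a stronger inhibitor, a higher number a weaker inhibitor. In this assay compound 1 gives > 100000 nM, which is a limit of the assay rather than a measured number. Within the data shown here, compound 2, `CN(C)c1nc2cc(Cl)c(Cl)cc2n1COCCO`, is the only other compound with a value here. In this assay compound 2 gives > 100000 nM, again a limit and not a number. Compound 1 therefore stands at the edge of what the assay can report, and compound 2 stands there with it, since both values sit at the limit of > 100000 nM in this assay, at which 2 of the 2 values shown sit. Among the measured compounds shown here, no step between measured compounds is known, so there is no measured change to lean on.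

Compound 3, `Nc1nc2c(Cl)c(Cl)ccc2n1COCCO`, has not yet been measured in this assay. It differs from compound 1 by amino in place of chloro on an aromatic carbon of the shared core. With both known compounds at the limit, the step from compound 1 to compound 3 is expected to be a number no higher from compound 1 to compound 3 (the limit leaves the size open), meaning no change beyond the scatter. Compound 3 is thus estimated at 100000 nM, within a range of 30000 nM to 300000 nM, and will most likely again be reported only as a limit.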

Compound 3, half-maximal inhibitory concentration: > 100000 nM
Compound 3 was reported as a limit; the forecaster's own chance of this, stated with the estimate: 85%; the middle value lies on the limit itself.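

No step from compound 1 to compound 3 can be read in this assay, because both are reported only as limits of the assay: the limit of > 100000 nM in this assay, at which 3 of the 3 values shown sit.

The compounds shown leave open whether amino in place of chloro on an aromatic carbon changes inhibition at all, and where each of the three compounds would fall on a measured scale.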